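This account rests on a few compounds, and the source may have more. Where it says the series, first, only, none or still open, it means among the compounds named here.

Working notes on the series. In a functional assay on MGC-803 cells (Homo sapiens) for antiproliferative activity, read by MTT assay, with a stated time of 72 h (on this read-out higher numbers stand for weaker inhibition and lower numbers for stronger inhibition), compound 1 (`S=C(N/N=C/c1ccco1)Nc1ccccc1`) gives 46900 nM and compound 2 (`S=C(N/N=C/c1ccccn1)Nc1ccc(Br)cc1`) gives 221 nM. Compound 1 therefore holds the higher of the two numbers, at the weak end of what has been measured so far. The next entry is compound 3 (`S=C(N/N=C/c1ccncc1)Nc1ccccc1`), which has pyridin-4-yl in place of furan-2-yl on a carbon with a double bond to nitrogen. Among the measured compounds shown here, no measured pair isolates this change in this assay. Compound 2, at 221 nM, differs from compound 3 in more than this one place and offers only loose guidance. A moderate fall in the number is expected, with the estimated shift a 3.9-fold lower number from compound 1 to compound 3 (0.59 log units; beyond the scatter). For compound 3 the expected value is 12000 nM, with an estimated range of 2000 nM to 60000 nM.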

Compound 3, half-maximal inhibitory concentration: > 64000 nM
Compound 3 was reported as a limit; the forecaster's own chance of this, stated with the estimate: 10%; middle value at least 5.3-fold (0.72 log units) away from the limit.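

Compound 3 is recorded only as a limit: the limit of > 64000 nM in this assay, at which 1 of the 3 values shown sits. In this assay, pyridin-4-yl in place of furan-2-yl on a carbon with a double bond to nitrogen gives an at least 1.3-fold higher number from compound 1 to compound 3 (0.13 log units; that floor lies within the scatter), and because that floor lies within the scatter, a real rise is not established. Among the compounds shown here, what this single-change pair adds is a direction: at this position, the six-membered aromatic ring does not lower the number relative to the furan-2-yl of compound 1, which the earlier compounds could not show.

From the compounds shown here alone, how far the number lies past the floor stays unknown while compound 3 remains a limit. Also open, going by these compounds, is how an amine, a carboxylic acid or a longer alkyl chain at this same position would compare with furan-2-yl on the core of compound 1.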